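Bis-thiourea linked series: cytotoxicity working notes

The source may hold more compounds than are shown below. What is called first, only, known or untested is meant among the compounds shown, and "the series" means these compounds.

Measured so far:
compound 1 `NC(=S)Nc1cccc(OCCCCCN2CCN(c3cccnc3)C2=O)c1` — > 50000 nM
compound 2 `NC(=S)Nc1cccc(OCCCCCCCCNC(=S)Nc2cc(Cl)cc(Cl)c2)c1` — 12000 nM

In an ADME assay on Huh-7 cells (Homo sapiens) for cytotoxicity (on this read-out lower numbers stand for higher toxicity in this test and higher numbers for lower toxicity in this test), compound 1 reaches only a limit, > 50000 nM. Among the compounds with values here, compound 2 gives 12000 nM in this assay, the only actual number so far. The other entry, belonging to compound 1, sits at the limit of > 50000 nM in this assay, at which 1 of the 2 values shown sits. Compound 3 `NC(=S)Nc1cccc(OCCCCCCCCNC(=S)Nc2ccc(Cl)cc2)c1` differs from compound 2 by 4-chlorophenyl in place of 3,5-dichlorophenyl on an amide-type nitrogen. Within the data shown here, no measured step of this kind exists; the change is expected to move the read-out modestly towards lower toxicity, about a 1.7-fold higher number from compound 2 to compound 3 (0.22 log units; within the scatter), roughly at the edge of the scatter. Compound 3 is therefore estimated at 20000 nM, between 8000 nM and 50000 nM.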

Compound 3, half-maximal cytotoxic concentration: 18000 nM
Compound 3: middle estimate off by 1.1-fold (0.05 log units), on the high side; the measured number falls inside the stated range.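

Putting 4-chlorophenyl in place of 3,5-dichlorophenyl on the amide-type nitrogen gives, in this assay, a 1.5-fold higher number from compound 2 to compound 3 (0.18 log units; within the scatter). The two aryl groups are therefore not separated in this test, and one chlorine can go from this position without a shift beyond the scatter. The data shown offer no explanation for the size of this step.

Open, going by these compounds, is how an unsubstituted phenyl or a pyridine ring on this nitrogen would read. Also open, on these data alone, is whether a longer chain would move the number beyond the scatter.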